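Adding Chloro to a Shared Core: Expected Cytotoxicity

The compounds below may be only part of what the source reports. "The series", "measured", "known", "first", "only" and "open" are said of these compounds alone.

Of the compounds shown here, three built on one shared core have been tested in a functional assay on C6 cells (Rattus norvegicus) for cytotoxicity, read by MTT assay, with a stated time of 24 h; on this read-out lower numbers stand for stronger inhibition and higher numbers for weaker inhibition. Compound 2 `Cc1cc(-c2nc3ccccc3o2)ccc1NC(=O)CN1CCN(CCCN(C)C)CC1` gives 38700 nM in this assay. Compound 1 `Cc1cc(-c2nc3cc(Cl)ccc3o2)ccc1NC(=O)CN1CCN(CCCN(C)C)CC1` differs from compound 2 by chloro in place of hydrogen on an aromatic carbon. In this assay compound 1 gives 14200 nM. That step is a 2.7-fold lower number from compound 2 to compound 1 (0.44 log units; beyond the scatter). Compound 3 `CN(C)CCCN1CCN(CC(=O)Nc2ccc(-c3nc4ccccc4o3)cc2)CC1` differs from compound 2 by hydrogen in place of methyl on an aromatic carbon. In this assay compound 3 gives 42300 nM. That step is a 1.1-fold higher number from compound 2 to compound 3 (0.04 log units; within the scatter), so the two cores stand at numbers within the usual scatter of each other.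

Compound 4 `CN(C)CCCN1CCN(CC(=O)Nc2ccc(-c3nc4cc(Cl)ccc4o3)cc2)CC1` has not yet been measured. It differs from compound 3 by chloro in place of hydrogen on an aromatic carbon. Within the data shown here, this is the same change that turns compound 2 into compound 1: the place where the chloro enters is described in the same words for both pairs, and the chloro is the only group that changes. Because the earlier step was a 2.7-fold lower number from compound 2 to compound 1 (0.44 log units; beyond the scatter), a step of similar size is expected here, and the estimated step is a 2.7-fold lower number from compound 3 to compound 4 (0.43 log units; beyond the scatter). This expectation rests on a single measured pair, so its exact size is uncertain. Compound 4 is therefore estimated at 15700 nM in this assay. The expected lower end for compound 4 is 7000 nM, and for compound 4 the expected upper end is 35000 nM.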

Compound 4, half-maximal inhibitory concentration: 910 nM
Estimate against measurement, compound 4: 17-fold (1.24 log units) above, outside the stated range (below it).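

In this assay, chloro in place of hydrogen gave a 46-fold lower number from compound 3 to compound 4 (1.67 log units; beyond the scatter), a much larger step than the same change produced on the core that carries the methyl: the same change on two cores in this assay, a 2.7-fold lower number (0.44 log units; beyond the scatter) from compound 2 to compound 1 and a 46-fold lower number (1.67 log units; beyond the scatter) from compound 3 to compound 4, 17-fold (1.23 log units) apart, beyond the scatter of two such steps

The same four compounds can be read through the other change, hydrogen in place of methyl, which gave a 16-fold lower number from compound 1 to compound 4 (1.19 log units; beyond the scatter) with the chloro present but no step beyond the scatter without it: the same change on two cores in this assay, a 1.1-fold higher number (0.04 log units; within the scatter) from compound 2 to compound 3 and a 16-fold lower number (1.19 log units; beyond the scatter) from compound 1 to compound 4, 17-fold (1.23 log units) apart, beyond the scatter of two such steps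

The number fell with chloro on both cores, but the size of the step did not carry over, so in these four compounds the effect of the chloro depends on whether the methyl is present, and the reverse also holds; these two pairs do not show why this happens, or whether it would hold for any other pair in the series.

The compounds shown leave open whether this large step belongs to chloro alone or would also appear with bromo or fluoro at the same place, and whether an ethyl in place of the methyl would shrink it as the methyl does. They also leave open whether a longer chain in place of the one that ends in the dimethylamino group would keep the low number of compound 4.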